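The compounds below may be only part of what the source reports. "The series", "measured", "known", "first", "only" and "open" are said of these compounds alone.

Measured compounds in a functional assay on thoracic aorta (Rattus norvegicus, strain Wistar), with a stated time of 15 min; on this read-out higher numbers stand for an effect only at larger amounts of compound and lower numbers for an effect already at smaller amounts:
- compound 3, `COc1ccc(Br)cc1C(C)NC(=O)NS(=O)(=O)c1ccc(Cl)cc1`: compound 3 gives 80900 nM
- compound 2, `Cc1ccc(OCc2ccccc2)c(C(C)NC(=O)N(C)S(=O)(=O)c2ccc(Cl)cc2)c1`: compound 2 gives 142000 nM
- compound 1, `COc1ccc(Br)cc1C(C)NC(=O)NS(=O)(=O)c1ccccc1`: compound 1 reaches only a limit of this assay, > 300000 nM

Among the measured compounds shown here, the one change measured within the set is hydrogen in place of chloro on an aromatic carbon, which gave an at least 3.7-fold higher number from compound 3 to compound 1 (0.56 log units; beyond the scatter); the end point is the limit of > 300000 nM in this assay, at which 1 of the 3 values shown sits. The difference between the cores of compound 2 and compound 3 is not broken down here. The unmeasured compound 4, `Cc1ccc(OCc2ccccc2)c(C(C)NC(=O)N(C)S(=O)(=O)c2ccccc2)c1`, carries the same change on the core of compound 2: hydrogen in place of chloro on an aromatic carbon. The step from compound 3 to compound 1 is expected to repeat, so a 3.9-fold higher number from compound 2 to compound 4 (0.59 log units; beyond the scatter) is estimated in this assay. For compound 4 the expected value is 550000 nM, between 250000 nM and 1500000 nM, and a result reported only as a limit is considered likely.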

Compound 4, half-maximal effective concentration: 68200 nM
Estimate against measurement, compound 4: 8.1-fold (0.91 log units) above; measured number outside the range, below it.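

In this assay, hydrogen in place of chloro gives a 2.1-fold lower number from compound 2 to compound 4 (0.32 log units; beyond the scatter), so the step does not keep its direction from one core to the other: the same change on two cores in this assay, an at least 3.7-fold higher number (0.56 log units; beyond the scatter) from compound 3 to compound 1 and a 2.1-fold lower number (0.32 log units; beyond the scatter) from compound 2 to compound 4, at least 7.7-fold (0.88 log units) apart, beyond the scatter of two such steps. The change 4-chlorophenyl to phenyl therefore cannot be carried between these two cores as a fixed increment, and the earlier step ends at a limit of the assay rather than at a number: the limit of > 300000 nM in this assay, at which 1 of the 4 values shown sits. The two pairs do not show which of the differences between the cores goes with the opposite directions, and they do not establish a rule for any other core.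

Open, from the compounds shown here alone, is how a fluoro, methyl or methoxy group in place of the chloro would behave on each core. Going by these compounds, an amine or a carboxylic acid at that place also remains open.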